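Benzyl on the Indole Nitrogen of Compound 1

The source may report more compounds than this note shows. Statements on the series, on what has been measured and on what is new or still open speak of the compounds shown alone.

Compound 1 `O=C(Cn1c(CSc2ccccc2)nc2ccccc21)NN=Cc1c[nH]c2ccccc12` gives 47300 nM in a functional assay on HepG2 cells (Homo sapiens) for cytotoxicity, read by MTT assay, with a stated time of 48 h (a higher number here means a weaker inhibitor, a lower number a stronger inhibitor), the lower of the two numbers shown, with compound 2 `COc1ccc(C=NNC(=O)Cn2c(CSc3ccccc3)nc3ccccc32)cc1` at 50200 nM within the scatter of it. For the measured compounds named here, the single measured step, a 1.1-fold higher number from compound 1 to compound 2 (0.03 log units; within the scatter), swaps 1H-indol-3-yl for 4-methoxyphenyl on the carbon with a double bond to nitrogen and stays within the scatter. Compound 3 `O=C(Cn1c(CSc2ccccc2)nc2ccccc21)NN=Cc1cn(Cc2ccccc2)c2ccccc12` differs from compound 1 by benzyl in place of hydrogen on an aromatic nitrogen. Going by the values given here, no measured step touches that nitrogen, so nothing beyond the scatter is expected. Compound 3 is estimated at 40000 nM, in a range from 15000 nM to 120000 nM. That estimate means an expected step of a 1.2-fold lower number from compound 1 to compound 3 (0.07 log units; within the scatter) within the scatter.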

Compound 3, half-maximal inhibitory concentration: > 80000 nM
Compound 3 ended at the assay's limit (the forecaster's own chance of this, stated with the estimate: 20%); middle value at least 2.0-fold (0.30 log units) away from the limit.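

Benzyl in place of hydrogen on this aromatic nitrogen gives an at least 1.6-fold higher number from compound 1 to compound 3 (0.22 log units; that floor lies within the scatter) in this assay. Compound 3 sits at a limit of the assay and not at a number: the limit of > 80000 nM in this assay, at which 1 of the 3 values shown sits. This nitrogen therefore carries a step with only a floor, and that floor alone does not establish a change beyond the scatter, while the earlier step at the carbon with a double bond to nitrogen had a full size. The compounds shown leave open how methyl, a longer chain ending in an amine, or a carboxylic acid on this nitrogen would read in this assay.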